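Swapping one ring on compound 1

The compounds below may be only part of what the source reports. "The series", "measured", "known", "first", "only" and "open" are said of these compounds alone.

Measured so far in an ADME assay on cells (Hepatocyte, Rattus norvegicus) for metabolic stability (a higher number here means that the compound lasts longer, a lower number that the compound disappears faster), as follows:
- compound 1 `O=C(C1CCN(c2ncccn2)CC1)N1N=CC[C@H]1c1ccccc1` gives 0.137 h
- compound 2 `N#Cc1ccc(N2CCC(C(=O)N3N=CC[C@H]3c3cc(F)cc(F)c3)CC2)nn1` gives 2.08 h
- compound 3 `CC1=NN(C(=O)C(C)(C)C)[C@H](c2ccccc2)C1` gives 0.0417 h

Compound 1 at 0.137 h holds the second highest of these three numbers. It lies above compound 3 and below compound 2, and both gaps are beyond the scatter of repeated measurements.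

The next compound to be tested is compound 4 `O=C(C1CCN(c2cccnn2)CC1)N1N=CC[C@H]1c1ccccc1` and it has pyridazin-3-yl in place of pyrimidin-2-yl on an amine nitrogen in a ring (full count: pyridazin-3-yl in place of pyrimidin-2-yl on an amine nitrogen in a ring). The two compounds have the same atoms, joined differently, so the change is small on paper. Among the compounds with values here, no measured pair here isolates this swap, which makes any forecast uncertain.

Within the data shown here, the only hint comes from compound 2 at 2.08 h which also carries a substituted pyridazin-3-yl on that amine nitrogen. It differs elsewhere too, so it points upward only weakly.

In this assay the expected change is a small rise close to the scatter, estimated as a 2.0-fold higher number from compound 1 to compound 4 (0.31 log units; beyond the scatter) and no more than that. For compound 4 the estimated half-life is 0.28 h with an expected range from 0.1 h to 0.75 h as the likely span.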

Compound 4, half-life: < 0.517 h
Compound 4: only a limit was reported; the forecaster's own chance of this, stated with the estimate: 3%; the middle value does not contradict the limit.
By their numbers in this assay, from the lowest: compound 3; then compound 1; then compound 2.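

In this assay compound 4 gives < 0.517 h, which is a limit and not a number. The step from compound 1 to compound 4 therefore cannot be read. The compounds shown leave open whether pyridazin-3-yl in place of pyrimidin-2-yl on an amine nitrogen in a ring changes the half-life, and in which direction.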